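Fluoro for allyloxy: expected cytotoxicity of compound 3

The source may hold more compounds than are shown below. What is called first, only, known or untested is meant among the compounds shown, and "the series" means these compounds.

Compound 1 `COc1cc(C2=C(c3cc(C)c(OC)c(C)c3)C(O)CC2=O)cc(OC)c1OC` and compound 2 `C=CCOc1cc(C2=C(c3cc(OC)c(OC)c(OC)c3)C(=O)C(O)C2)ccc1OC` have been run in an ADME assay on ECV-304 cells (Homo sapiens) for cytotoxicity, read by MTT assay, with a stated time of 72 h; on this read-out higher numbers stand for weaker inhibition and lower numbers for stronger inhibition. In this assay compound 1 gives only a limit of the assay, > 100 ug/mL. In this assay compound 2 likewise gives only a limit of the assay, > 100 ug/mL. For the measured compounds named here, compound 2 thus stands at the same limit as the one other value shown, so the limit of > 100 ug/mL in this assay, at which 2 of the 2 values shown sit, covers both measured entries and no number separates them. Going by the values given here, no step between two measured compounds is available in this set.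

Compound 3 `COc1ccc(C2=C(c3cc(OC)c(OC)c(OC)c3)C(=O)C(O)C2)cc1F` has not yet been measured in this assay. Its change from compound 2 is fluoro in place of allyloxy on an aromatic carbon, on an aromatic carbon of a six-membered aromatic ring of carbon only, ortho to a methoxy group and meta to a large group. With both measured values sitting at the limit, the expected step is a number no higher from compound 2 to compound 3 (the limit leaves the size open), none beyond the scatter. Compound 3 is therefore expected to give 100 ug/mL in this assay, within 40 ug/mL to 250 ug/mL, most likely again reported only as a limit rather than a number.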

Compound 3, half-maximal inhibitory concentration: 19.5 ug/mL
Compound 3: middle estimate off by 5.1-fold (0.71 log units), on the high side, outside the stated range (below it).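

Fluoro in place of allyloxy, on an aromatic carbon ortho to a methoxy group and meta to a large group, gives in this assay an at least 5.1-fold lower number from compound 2 to compound 3 (0.70 log units; beyond the scatter). This position can therefore move the read-out, which compound 1 and compound 2 could not show while both sat at a limit, and compound 3 is the only one of the three with a number rather than a limit. Compound 2 stands only at a limit, so the step sets a floor for the change and not its size: the limit of > 100 ug/mL in this assay, at which 2 of the 3 values shown sit.

The compounds shown do not separate the loss of allyloxy from the gain of fluoro, and a chloro, a hydroxyl or an amine on the same aromatic carbon would bear on that question. Going by these compounds, compound 1 differs from compound 3 in more than one place, so it remains open whether fluoro would give a similar step on the core of compound 1, and whether a longer chain ending in an ether would stay at the limit in this assay.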